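From methyl to oxolan-3-yl on an aromatic nitrogen

A few compounds are considered here, and "the series" means these few. Any claim that something is new, unique, unknown or untested is made for them only; others in the source may bear on it.

Compound 1 `CC(C)Oc1cc(-c2cncc(-c3cnn(C4COC4)c3)c2)ccc1C(N)=O`: 200 nM
Compound 2 `CC(C)Oc1cc(-c2cncc(-c3cnn(C)c3)c2)ccc1C(N)=O`: 400 nM

Both were measured in an assay on cells for inhibition of MAP kinase-interacting serine/threonine-protein kinase 1 (Homo sapiens), read by mobility shift assay, with stated times of 10 min and 60 min, in the presence of a further agent that is not named here; a higher number here means a weaker inhibitor, a lower number a stronger inhibitor. Compound 2 carries the higher of the two numbers, yet the step of a 2.0-fold higher number from compound 1 to compound 2 (0.30 log units; within the scatter) stays within the scatter. Compound 3 `CC(C)Oc1cc(-c2cncc(-c3cnn(C4CCOC4)c3)c2)ccc1C(N)=O` differs from compound 2 by oxolan-3-yl in place of methyl on an aromatic nitrogen. For the measured compounds named here, the one measured step that bears on this change is a 2.0-fold higher number from compound 1 to compound 2 (0.30 log units; within the scatter), which also exchanges methyl for a small saturated ring at that nitrogen and stays within the scatter. The step of a 1.6-fold lower number from compound 2 to compound 3 (0.20 log units; within the scatter) is therefore expected to be small, at most a slight move toward a lower number. Compound 3 is estimated at 250 nM, in a range from 100 nM to 600 nM.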

Compound 3, half-maximal inhibitory concentration: 120 nM
Beside the measured number, compound 3's estimate is 2.1-fold (0.32 log units) above it; the measured number falls inside the stated range.
By their numbers in this assay, from the lowest: compounds 3, 1 and 2 (each within the scatter of the next, the first and the last beyond it).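

In this assay, replacing methyl on this aromatic nitrogen with a saturated oxygen-containing ring now gives a step beyond the scatter (a 3.3-fold lower number from compound 2 to compound 3 (0.52 log units; beyond the scatter)). The two rings themselves stay unseparated, as oxolan-3-yl in place of oxetan-3-yl gives only a step within the scatter (a 1.7-fold lower number from compound 1 to compound 3 (0.22 log units; within the scatter)). Nothing given here accounts for the step from methyl.

The compounds shown leave open whether the oxygen in the ring matters, which a cyclopentyl group at this nitrogen would address. They also leave open how an amine such as piperidin-4-yl would compare.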